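Loss of the acid on the coumarin side chain

This account rests on a few compounds, and the source may have more. Where it says the series, first, only, none or still open, it means among the compounds named here.

Measured compounds:
Compound 1, `O=C(O)c1cc(=O)oc2cc(OCc3cccc(Cl)c3)ccc12`, gives 100000 nM in an assay on brain (strain Sprague-Dawley) for inhibition of Amine oxidase [flavin-containing] B (Rattus norvegicus), read by spectrophotometry; a lower number here means a stronger inhibitor, a higher number a weaker inhibitor.
Compound 2, `O=c1cc(CCO)c2ccc(OCc3cccc(Cl)c3)cc2o1`, gives 7.41 nM in this assay.
Compound 3, `O=C(O)CCc1cc(=O)oc2cc(OCc3cccc(Cl)c3)ccc12`, gives 1200 nM in this assay.

Compound 3 stands second highest of the three: nearest is compound 1, with an 83-fold lower number from compound 1 to compound 3 (1.92 log units; beyond the scatter), furthest is compound 2, with a 160-fold higher number from compound 2 to compound 3 (2.21 log units; beyond the scatter). Compound 4, `NC(=O)CNc1cc(=O)oc2cc(OCc3cccc(Cl)c3)ccc12`, differs from compound 3 by (carbamoylmethyl)amino in place of 2-carboxyethyl on an aromatic carbon. Within the data shown here, no measured step changes the carboxy group into an amide, so the comparison is indirect. Among the measured compounds shown here, the steps that bear on it are a 160-fold higher number from compound 2 to compound 3 (2.21 log units; beyond the scatter) and a 13000-fold lower number from compound 1 to compound 2 (4.13 log units; beyond the scatter), both large, both showing the carboxy-bearing compound with the higher number. Because of a 160-fold higher number from compound 2 to compound 3 (2.21 log units; beyond the scatter), a compound without a carboxy group is expected to give a lower number. Compound 4 is therefore estimated at 60 nM, within 6 nM to 600 nM, a step of a 20-fold lower number from compound 3 to compound 4 (1.30 log units; beyond the scatter) that is expected but uncertain.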

Compound 4, half-maximal inhibitory concentration: 49 nM
Compound 4: the middle estimate sits 1.2-fold (0.09 log units) above what was measured; low and high end bracket the measured number.
By their numbers in this assay, from the lowest: compound 2; then compound 4; then compound 3; then compound 1.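

Among the compounds shown, a carboxy-free group at this position again gives the lower number, now with a nitrogen attached directly to the ring: (carbamoylmethyl)amino in place of 2-carboxyethyl gives a 24-fold lower number from compound 3 to compound 4 (1.39 log units; beyond the scatter), and in place of carboxy gives a 2000-fold lower number from compound 1 to compound 4 (3.31 log units; beyond the scatter). It does not match 2-hydroxyethyl, however, with a 6.6-fold higher number from compound 2 to compound 4 (0.82 log units; beyond the scatter). Nothing measured here accounts for this order.

The compounds shown do not separate the amino link from the terminal amide. A 2-carbamoylethyl chain and a (carboxymethyl)amino group would tell these two changes apart.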